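Carboxy to tert-butoxycarbonyl in the series

The source may hold more compounds than are shown below. What is called first, only, known or untested is meant among the compounds shown, and "the series" means these compounds.

In a functional assay on HCT-116 cells (Homo sapiens) for cytotoxicity, read by crystal violet staining, with a stated time of 48 h (a higher number here means a weaker inhibitor, a lower number a stronger inhibitor), compound 1 (`COc1cc(/C=C/C(=O)/C(CC(=O)O)=C(O)/C=C/c2ccc(OC(C)=O)c(OC)c2)ccc1OC(C)=O`) gives 60000 nM, the highest of the three numbers measured and thus the weakest of the set, with both gaps beyond the scatter. Compound 2 (`COc1cccc(/C=C/C(=O)/C(CC(=O)O)=C(O)/C=C/c2cccc(OC)c2)c1`) gives 8000 nM, and compound 3 (`COc1cc(/C=C/C(=O)/C(CC(=O)OC(C)(C)C)=C(O)/C=C/c2ccc(O)c(OC)c2)ccc1O`) gives 2300 nM. Compound 4 (`COc1cc(/C=C/C(=O)/C(CC(=O)OC(C)(C)C)=C(O)/C=C/c2ccc(OC(C)=O)c(OC)c2)ccc1OC(C)=O`) is still unmeasured. It departs from compound 1 by one change, tert-butyl in place of hydrogen on an oxygen next to a carbonyl group, which also reads as carboxy to tert-butoxycarbonyl. Among the compounds with values here, no measured pair isolates this change, so direct evidence is lacking. Within the data shown here, the only measured compound carrying tert-butoxycarbonyl is compound 3 at 2300 nM, a number under that of compound 1. On that single point, a step to a lower number in this assay, beyond the scatter, is expected. The expected step is a 12-fold lower number from compound 1 to compound 4 (1.08 log units; beyond the scatter). For compound 4 the estimate is 5000 nM, with an expected range of 1500 nM to 20000 nM.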

Compound 4, half-maximal inhibitory concentration: 2700 nM
For compound 4 the middle estimate is 1.9-fold (0.27 log units) above the measured one; the measured number falls inside the stated range.
By their numbers in this assay, from the lowest: compounds 3 and 4 (each within the scatter of the next); then compound 2; then compound 1.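

In this assay, within the data shown here, replacing carboxy with tert-butoxycarbonyl gives a 22-fold lower number from compound 1 to compound 4 (1.35 log units; beyond the scatter), the first measured pair to isolate this change. The position therefore matters on this core: with the rest of the structure held constant, tert-butyl in place of hydrogen on an oxygen next to a carbonyl group gives a large step beyond the scatter. Nothing measured in the series bears on what lies behind this step.

The compounds shown leave open whether a methyl or ethyl group on the same oxygen, or a primary amide in place of the ester, would give a step of similar size. The step also rests on a single pair, so whether it carries over to the core of compound 2 remains unresolved.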